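Chloro to bromo on the benzoyl ring of compound 3

The compounds below may be only part of what the source reports. "The series", "measured", "known", "first", "only" and "open" are said of these compounds alone.

Measured compounds:
compound 1, `Cc1ccc(S/C(=C/c2c[nH]c3ccc(Cl)cc23)C(=O)c2ccc(Br)cc2)cc1`, 1000 nM
compound 2, `Cc1ccc(S/C(=C/c2c[nH]c3ccc(Br)cc23)C(=O)c2ccc(Br)cc2)cc1`, 1000 nM
compound 3, `O=C(/C(=C\c1c(O)cc(O)cc1O)Sc1ccccc1Br)c1ccc(Cl)cc1`, a limit of the assay, > 100000 nM

In a functional assay on DU-145 cells (Homo sapiens) for inhibition, read by trypan blue exclusion, with a stated time of 96 h (on this read-out lower numbers stand for stronger inhibition of growth and higher numbers for weaker inhibition of growth), compound 1 gives 1000 nM and compound 2 gives 1000 nM. Compound 3 reaches only a limit of the assay in this assay, > 100000 nM. Compound 1 and compound 2 differ by bromo in place of chloro on an aromatic carbon, and the step of no change at the digits printed from compound 1 to compound 2 (within the scatter) is within the scatter. How the core of compound 3 differs from the core of compound 1 is not broken down here.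

Compound 4, `O=C(/C(=C\c1c(O)cc(O)cc1O)Sc1ccccc1Br)c1ccc(Br)cc1`, is not yet measured. It differs from compound 3 by bromo in place of chloro on an aromatic carbon. Going by the values given here, this is the same kind of change as the one from compound 1 to compound 2, not the same: there the aromatic carbon is part of a fused or bridged system of two rings, meta to a fused ring and para to a fused ring, while in compound 4 it sits on a six-membered aromatic ring of carbon only, para to a large group.

The step from compound 3 to compound 4 in this assay is expected to be a number no higher from compound 3 to compound 4 (the limit leaves the size open), because no change at the digits printed from compound 1 to compound 2 (within the scatter) showed no movement for the same kind of change and because compound 3 sits at the limit of > 100000 nM in this assay, at which 1 of the 3 values shown sits. Compound 4 is therefore expected to remain at the limit, with an estimate of 100000 nM. The expected range for compound 4 runs from 30000 nM to 300000 nM, and a limit rather than a number is the more likely report.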

Compound 4, concentration for 50% growth inhibition: > 100000 nM
Compound 4: only a limit was reported (the forecaster's own chance of this, stated with the estimate: 85%); the middle value lies on the limit itself.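

Compound 3 and compound 4 both stand at a limit of the assay in this assay, so the step between them cannot be read: the limit of > 100000 nM in this assay, at which 2 of the 4 values shown sit.

The compounds shown leave open whether bromo in place of chloro on an aromatic carbon changes growth inhibition at all on the core of compound 3, where neither compound gives a number.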